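Chloro for Fluoro on the Chain-Bound Phenyl Ring

The source may hold more compounds than are shown below. What is called first, only, known or untested is meant among the compounds shown, and "the series" means these compounds.

Compound 1, `O=C(/C=C\c1ccc([N+](=O)[O-])cc1)N1N=C(c2ccncc2)OC1c1c[nH]c2ccccc12`, and compound 2, `O=C(/C=C\c1ccccc1F)N1N=C(c2ccncc2)OC1c1c[nH]c2ccccc12`, share one core and differ only on the phenyl ring that hangs from the double-bonded chain. In an ADME assay on HeLa cells (Homo sapiens) for cytotoxicity, read by MTT assay, with a stated time of 72 h (a higher number here means a weaker inhibitor of growth, a lower number a stronger inhibitor of growth), compound 1 gives > 30 ug/mL, which is a limit of the assay rather than a number. In this assay compound 2 likewise gives > 30 ug/mL, again a limit. The step that the two limits leave unreadable from compound 1 to compound 2 therefore cannot be sized, because of the limit of > 30 ug/mL in this assay, at which 2 of the 2 values shown sit. Compound 2 thus stands at the limit, with no measured number to place it more closely.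

Compound 3, `O=C(/C=C\c1ccccc1Cl)N1N=C(c2ccncc2)OC1c1c[nH]c2ccccc12`, differs from compound 2 by chloro in place of fluoro on an aromatic carbon. Going by the values given here, no measured step bears directly on this change; the only measured step, a step that the two limits leave unreadable from compound 1 to compound 2, is unreadable, so it offers no direction or size to expect in this assay. With both measured values sitting at the limit, compound 3 is expected to sit there as well, with no step beyond the scatter, so the estimated step is a step that the limit leaves unreadable from compound 2 to compound 3. For compound 3 in this assay the estimate is 40 ug/mL, within a range from 15 ug/mL to 100 ug/mL.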

Compound 3, concentration for 50% growth inhibition: > 30 ug/mL
Compound 3 ended at the assay's limit (the forecaster's own chance of this, stated with the estimate: 80%); the middle value does not contradict the limit.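

The steps from compound 1 and from compound 2 to compound 3 cannot be read in this assay, because all three compounds give a limit rather than a number: the limit of > 30 ug/mL in this assay, at which 3 of the 3 values shown sit.

The compounds shown leave open how strongly any of them inhibits growth, and whether chloro in place of fluoro on an aromatic carbon changes that inhibition.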